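This account rests on a few compounds, and the source may have more. Where it says the series, first, only, none or still open, it means among the compounds named here.

Compound 1 `O=C(CN(c1ncnc2c1ncn2C1CCCCO1)C1CC1)N[C@@H](CO)C(=O)OCc1ccccc1`: in a functional assay on the whole organism (Tail, strain ICR) with Mus musculus as the target, in the tail flick test, with a stated time of 120 min, at a dose of 25 umol/kg by the oral route (a higher number here means a stronger effect of the compound at the dose given, a lower number a weaker effect), compound 1 gives 29.2%.
Compound 2 `CC(C)[C@H](NC(=O)CN(c1ncnc2c1ncn2C1CCCCO1)C1CC1)C(=O)OCc1ccccc1`: in this assay compound 2 gives 25.8%.
Compound 3 `C[C@H](NC(=O)CN(c1ncnc2c1ncn2C1CCCCO1)C1CC1)C(=O)OCc1ccccc1`: in this assay compound 3 gives 25.3%.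

Compound 3 stands lowest of the three numbers, yet its gaps to both others lie within the scatter: a number 0.5 percentage points lower from compound 2 to compound 3 (within the scatter) and a number 3.9 percentage points lower from compound 1 to compound 3 (within the scatter). Compound 4 `CC(C)(C)OC(=O)NCCCC[C@H](NC(=O)CN(c1ncnc2c1ncn2C1CCCCO1)C1CC1)C(=O)OCc1ccccc1` differs from compound 3 by 3-((tert-butoxycarbonyl)amino)propyl in place of hydrogen on a saturated chain carbon, two bonds along the chain from an amide-type nitrogen and a carbonyl carbon. The step that bears on this same place is a number 3.9 percentage points lower from compound 1 to compound 3 (within the scatter), and the further change on this chain, a number 3.4 percentage points lower from compound 1 to compound 2 (within the scatter), also stayed within the scatter. Nothing among these compounds points to a step beyond the scatter, so compound 4 is expected to give 26%, between 15% and 37%. The estimated step is a number 0.7 percentage points higher from compound 3 to compound 4 (within the scatter).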

Compound 4, a percentage reported as activity, at one dose (the size of the read-out at that dose, not a potency): 28.4%
For compound 4 the middle estimate is 2.4 percentage points below the measured one, within the range that was stated.
By their numbers in this assay, from the lowest: compounds 3, 2, 4 and 1 (each within the scatter of the next).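

In this assay the position takes 3-((tert-butoxycarbonyl)amino)propyl, with its 11 heavy atoms, without a step beyond the scatter (a number 3.1 percentage points higher from compound 3 to compound 4 (within the scatter)), and the same holds against isopropyl (a number 2.6 percentage points higher from compound 2 to compound 4 (within the scatter)) and against the hydroxy-bearing chain (a number 0.8 percentage points lower from compound 1 to compound 4 (within the scatter)). On this saturated chain carbon, all four compounds thus lie within the scatter of one another, even with this much longer carbamate-bearing chain in place. Nothing available explains this result. From the compounds shown here alone, whether a free primary amine or a carboxylic acid at the end of this chain would give a step beyond the scatter remains open.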